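From methyl to tert-butyl: an estimate for compound 4

This account rests on a few compounds, and the source may have more. Where it says the series, first, only, none or still open, it means among the compounds named here.

Three close analogues share one core: compound 1 `COc1ccc(SCc2ccc(C(=O)Nc3ccccc3N)cc2)cc1`, compound 2 `Nc1ccccc1NC(=O)c1ccc(CSc2cccc(F)c2)cc1` and compound 3 `Cc1ccc(SCc2ccc(C(=O)Nc3ccccc3N)cc2)cc1`. In a functional assay on SMMC-7721 cells (Homo sapiens) for inhibition, read by CCK-8 assay, with a stated time of 72 h, tested at 8 uM (a lower number here means less inhibition of growth, a higher number more inhibition of growth at the concentration tested), compound 3 gives 82.7%, which lies within the scatter of compound 1 at 80.1% and of compound 2 at 83%. Compound 4 `CC(C)(C)c1ccc(SCc2ccc(C(=O)Nc3ccccc3N)cc2)cc1` carries tert-butyl in place of methyl on an aromatic carbon. The closest evidence is the change to methyl from methoxy, a number 2.6 percentage points higher from compound 1 to compound 3 (within the scatter), joined by a number 2.9 percentage points higher from compound 1 to compound 2 (within the scatter) and a number 0.3 percentage points lower from compound 2 to compound 3 (within the scatter), all of them small. None of these steps introduces tert-butyl, so the range stays wide. The expected step is a number 2.7 percentage points lower from compound 3 to compound 4 (within the scatter), with no shift beyond the scatter anticipated. For compound 4 the estimated value is 80%, with an expected range of 68% to 89%.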

Compound 4, percent growth inhibition at one concentration: 46.1%
Beside the measured number, compound 4's estimate is 33.9 percentage points above it; measured number outside the range, below it.
By their numbers in this assay, from the lowest: compound 4; then compounds 1, 3 and 2 (each within the scatter of the next).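

In this assay, the step to tert-butyl is large, at a number 36.6 percentage points lower from compound 3 to compound 4 (beyond the scatter) and a number 34 percentage points lower from compound 1 to compound 4 (beyond the scatter), whereas methyl and methoxy had stayed within the scatter of each other. Going by these compounds alone, the aromatic carbon para to a large group therefore does not take every group alike, and the earlier compounds gave no sign of this limit. No evidence shown bears on what lies behind this fall. As far as these compounds go, it remains open whether an ethyl or isopropyl group here would stay with compound 3 or fall toward compound 4.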